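A few compounds are considered here, and "the series" means these few. Any claim that something is new, unique, unknown or untested is made for them only; others in the source may bear on it.

Of the compounds shown here, two sharing one core have so far been measured in a functional assay on HCT-116 cells (Homo sapiens) for antiproliferative activity, read by MTT assay, with a stated time of 72 h; on this read-out lower numbers stand for stronger inhibition and higher numbers for weaker inhibition. Compound 1, `O=S(=O)(c1ccc(-c2cnc(C3CC3)o2)cc1)N1CCCOc2ccc(F)cc21`, gives 24 nM in this assay, the lower of the two numbers. Compound 2, `COc1ccc2c(c1)OCCCN2S(=O)(=O)c1ccc(-c2cnc(C3CC3)o2)cc1`, gives 223 nM in this assay, a higher number that lies beyond the scatter of repeated measurements, so compound 1 is the stronger of the pair. Compound 3, `Cc1ccc2c(c1)N(S(=O)(=O)c1ccc(-c3cnc(C4CC4)o3)cc1)CCCO2`, has not yet been measured in this assay. It differs from compound 1 in one place: methyl in place of fluoro on an aromatic carbon. Within the data shown here, no measured pair shows what a change of this kind does to the number in this assay, so there is no direct precedent to lean on. The change is a single exchange on one aromatic carbon, leaving the rest of the molecule untouched, and the expectation is a small step from compound 1 to compound 3, a 1.5-fold higher number from compound 1 to compound 3 (0.16 log units; within the scatter), most likely within the scatter or at most slightly toward a higher number. Compound 3 is therefore expected to give about 35 nM in this assay, with a likely range from 12 nM to 100 nM.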

Compound 3, half-maximal inhibitory concentration: 29 nM
For compound 3 the middle estimate is 1.2-fold (0.08 log units) above the measured one, and the stated range covers the measured number.
By their numbers in this assay, from the lowest: compounds 1 and 3 (each within the scatter of the next); then compound 2.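

In this assay, among these compounds, the exchange of fluoro for methyl on this aromatic carbon gives a 1.2-fold higher number from compound 1 to compound 3 (0.08 log units; within the scatter), the first direct reading of a change at this position, and on this read-out the two groups cannot be told apart. Among the compounds shown here, the exchange swaps one heavy atom for one heavy atom, with no ring, hydrogen-bond donor, hydrogen-bond acceptor or net charge on either side, so this pair shows that the position can carry either fluoro or methyl with the number staying within the scatter, but it tests only this narrow swap. No measurement at hand accounts for how close the two numbers lie.

The compounds shown leave open what an amine, a carboxylic acid or a longer chain such as butyl on this same aromatic carbon would do to the number, and whether a plain hydrogen there would stay level with compound 1 and compound 3. They also leave open whether fluoro and methyl would remain this close on other carbons of the ring, as a single pair speaks for this one place only.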